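This account rests on a few compounds, and the source may have more. Where it says the series, first, only, none or still open, it means among the compounds named here.

Measured so far
compound 1 `O=C(OCc1ccccc1)c1coc(-c2ccccc2)n1` gives 2.7%
compound 2 `CC(C)(C)OC(=O)c1coc(-c2ccccc2)n1` gives 42%

In an ADME assay on microsomes from liver (Rattus norvegicus, strain Sprague-Dawley) for metabolic stability, read by LC-MS, with a stated time of 15 min, tested at 20 uM (a lower number here means that less of the compound is left, a higher number that more of the compound is left), compound 1 gives 2.7% and holds the lower of the two numbers, with compound 2 as its nearest neighbour. Compound 3 `O=C(OCc1ccccc1)c1coc(-c2ccccc2OCc2ccccc2)n1` keeps the benzyl group of compound 1 and differs from it by benzyloxy in place of hydrogen on an aromatic carbon as benzyloxy in place of hydrogen on an aromatic carbon, ortho to a large group.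

Going by the values given here, the only measured step (a number 39.3 percentage points higher from compound 1 to compound 2 (beyond the scatter)) is large, but it comes from tert-butyl in place of benzyl on an oxygen next to a carbonyl group. That is a different place from the new change, so it sets no size for it, and compound 3 retains the benzyl group. Among the compounds with values here, no measured compound carries a substituent at the new place. Compound 1 at 2.7% leaves little room for a fall, and nothing measured points to a rise, so no step beyond the scatter is expected in this assay for this change. The expected step is a number 0.3 percentage points higher from compound 1 to compound 3 (within the scatter) and stays within the scatter. The estimated value for compound 3 is 3% with a range of 0.5% to 12% as the working figure.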

Compound 3, percent of the compound remaining: 3.5%
Estimate against measurement, compound 3: 0.5 percentage points below; the measured number falls inside the stated range.
By their numbers in this assay, from the lowest: compounds 1 and 3 (each within the scatter of the next); then compound 2.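

In this assay, benzyloxy in place of hydrogen on an aromatic carbon, ortho to a large group, gives a number 0.8 percentage points higher from compound 1 to compound 3 (within the scatter), so a group of 8 heavy atoms with a further six-membered aromatic ring enters at this place without a change that can be told from the scatter. Going by these compounds alone, with the benzyl group kept, the only step beyond the scatter remains a number 39.3 percentage points higher from compound 1 to compound 2 (beyond the scatter), which belongs to the oxygen next to a carbonyl group and not to this place, and compound 1 at 2.7% stands so low that the new result speaks against a rise but says little about a fall. The data at hand offer no explanation for this flat step.

Open, on these data alone, is whether benzyloxy at this place would read the same with tert-butyl in place of benzyl, where compound 2 at 42% leaves room for a move either way. Also open, as far as these compounds go, is how a smaller methoxy group, an amine or a carboxylic acid would read at this place.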